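Methoxy in Place of Bromo on Two Related Cores

The source may report more compounds than this note shows. Statements on the series, on what has been measured and on what is new or still open speak of the compounds shown alone.

Four compounds are compared, differing in one substituent and in the core that carries it. Compound 1 `COc1ccc(/C=C/C(=O)C(=Cc2cc(Br)c(O)c(OC)c2)C(=O)/C=C/c2ccc(OC)cc2OC)c(OC)c1` bears a bromo group, and compound 2 `COc1ccc(/C=C/C(=O)C(=Cc2cc(OC)c(O)c(OC)c2)C(=O)/C=C/c2ccc(OC)cc2OC)c(OC)c1` has a methoxy in its place. In a functional assay on HepG2 cells (Homo sapiens) for antiproliferative activity, read by sulforhodamine B assay, with a stated time of 48 h (a lower number here means a stronger inhibitor, a higher number a weaker inhibitor), compound 1 gives 1190 nM, while compound 2 gives 320 nM. The step of a 3.7-fold lower number from compound 1 to compound 2 (0.57 log units; beyond the scatter) corresponds to methoxy in place of bromo on an aromatic carbon.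

Compound 3 `COc1cc(OC)c(/C=C/C(=O)C(=Cc2cc(Br)c(O)c(OC)c2)C(=O)/C=C/c2c(OC)cc(OC)cc2OC)c(OC)c1` and compound 4 `COc1cc(OC)c(/C=C/C(=O)C(=Cc2cc(OC)c(O)c(OC)c2)C(=O)/C=C/c2c(OC)cc(OC)cc2OC)c(OC)c1` form the matching pair on a second core; how this core differs from that of compound 1 is not broken down here. In this assay compound 3 gives 660 nM. The change to compound 4 is methoxy in place of bromo on an aromatic carbon, made at a place described in exactly the same way as before, so it counts as the same change.

Among the measured compounds shown here, only one measured instance of this change exists, and it moved the number clearly. The expected step is therefore a 3.7-fold lower number from compound 3 to compound 4 (0.56 log units; beyond the scatter), resting on a 3.7-fold lower number from compound 1 to compound 2 (0.57 log units; beyond the scatter). Compound 4 is accordingly estimated at 180 nM, with the likely range running from 90 nM to 400 nM.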

Compound 4, half-maximal inhibitory concentration: 510 nM
For compound 4 the middle estimate is 2.8-fold (0.45 log units) below the measured one; measured number above the stated range.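

On the second core, methoxy in place of bromo gives a 1.3-fold lower number from compound 3 to compound 4 (0.11 log units; within the scatter), so the clear drop in the number seen on the core of compound 1 does not reappear in this assay. Among the compounds shown here, the two steps differ by more than the usual scatter of repeated measurements would allow, which shows that the size of this change depends on the core that carries it, and that a step measured on one of these cores cannot simply be transferred to the other: the same change on two cores in this assay, a 3.7-fold lower number (0.57 log units; beyond the scatter) from compound 1 to compound 2 and a 1.3-fold lower number (0.11 log units; within the scatter) from compound 3 to compound 4, 2.9-fold (0.46 log units) apart, beyond the scatter of two such steps With only two pairs, this does not show which structural difference between the cores matters, why the steps differ, or how the change would behave on a third core.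

The compounds shown carry only bromo or methoxy at this place, so how a chloro group, an amine or a longer chain such as ethoxy would behave there remains open. Also open, going by these compounds, is whether the two cores would diverge in the same way for any of those groups.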